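This account rests on a few compounds, and the source may have more. Where it says the series, first, only, none or still open, it means among the compounds named here.

Notes on the series. Compound 1 `N#Cc1c(-c2ccccc2Cl)c(C#N)c(=O)n(/N=C/c2cn(-c3ccccc3)nc2-c2ccccc2)c1N` carries the 2-chlorophenyl group on its core. In an ADME assay on HeLa cells (Homo sapiens) for cytotoxicity, read by MTT assay (on this read-out higher numbers stand for weaker inhibition and lower numbers for stronger inhibition), compound 1 gives > 200 ug/mL, which is a limit of the assay rather than a number. Compound 2 `Cc1ccc(-c2c(C#N)c(N)n(/N=C/c3cn(-c4ccccc4)nc3-c3ccccc3)c(=O)c2C#N)cc1` carries 4-methylphenyl instead. In this assay compound 2 likewise returns a limit, > 200 ug/mL. The step that the two limits leave unreadable from compound 1 to compound 2 therefore cannot be read, since the limit of > 200 ug/mL in this assay, at which 2 of the 2 values shown sit, holds both values. Compound 2 thus stands at the limit, with no measured number beside it.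

Compound 3 `COc1ccc(-c2c(C#N)c(N)n(/N=C/c3cn(-c4ccccc4)nc3-c3ccccc3)c(=O)c2C#N)cc1` differs from compound 2 by methoxy in place of methyl on an aromatic carbon. For the measured compounds named here, the only measured step bears on that same aryl group and is unreadable, so no size or direction can be predicted for compound 3 in this assay beyond an expected return of the limit. The estimate for compound 3 is 250 ug/mL, ranging from 150 ug/mL to 600 ug/mL, which is expected to correspond to a step that the limit leaves unreadable from compound 2 to compound 3.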

Compound 3, half-maximal inhibitory concentration: > 200 ug/mL
Compound 3: a limit, no number; the forecaster's own chance of this, stated with the estimate: 85%; the middle value lies beyond the limit too.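

No new step can be read among compound 1, compound 2 and compound 3 in this assay, since all three values are held by one limit: the limit of > 200 ug/mL in this assay, at which 3 of the 3 values shown sit.

The compounds shown leave open how these three aryl variants rank in this assay, and whether any aryl group on the shared core would give a readable number there.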